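From Compound 3 to Compound 4: One Group Exchanged

A few compounds are considered here, and "the series" means these few. Any claim that something is new, unique, unknown or untested is made for them only; others in the source may bear on it.

Compound 1 (`CC1=CC[C@H]2[C@H](CC[C@]2(C)O)C(C)(C)[C@@H]1CC[C@H]1[C@]2(C)CC[C@H](OC(=O)NS(=O)(=O)c3ccc(C)cc3)C(C)(C)O[C@H]2CC[C@@]1(C)O`): > 50000 nM (a limit)
Compound 2 (`COc1ccc(C(=O)O[C@H]2CC[C@]3(C)[C@H](CC[C@@](C)(O)[C@H]3CC[C@@H]3C(C)=CC[C@H]4[C@H](CC[C@]4(C)O)C3(C)C)OC2(C)C)cc1`): 41700 nM
Compound 3 (`CC1=CC[C@H]2[C@H](CC[C@]2(C)O)C(C)(C)[C@@H]1CC[C@H]1[C@]2(C)CC[C@H](OC(=O)c3cccc([N+](=O)[O-])c3)C(C)(C)O[C@H]2CC[C@@]1(C)O`): 36000 nM

These three compounds share one core and differ in the group on a carbonyl carbon. In a functional assay on MCF7 cells (Homo sapiens) for antiproliferative activity, read by MTT assay, with a stated time of 72 h (a higher number here means a weaker inhibitor, a lower number a stronger inhibitor), compound 1 gives > 50000 nM as its result, and this is a limit of the assay, not a number. In this assay compound 3 gives 36000 nM and compound 2 gives 41700 nM as their values, and these two cannot be told apart.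

Compound 4 (`CC1=CC[C@H]2[C@H](CC[C@]2(C)O)C(C)(C)[C@@H]1CC[C@H]1[C@]2(C)CC[C@H](OC(=O)c3ccc(C(F)(F)F)c(F)c3)C(C)(C)O[C@H]2CC[C@@]1(C)O`) has not been measured. It differs from compound 3 by a single exchange (3-fluoro-4-(trifluoromethyl)phenyl in place of 3-nitrophenyl on a carbonyl carbon), with 3-fluoro-4-(trifluoromethyl)phenyl in place of 3-nitrophenyl on a carbonyl carbon.

The closest guide is another exchange of one substituted phenyl for another at that carbon, a 1.2-fold lower number from compound 2 to compound 3 (0.06 log units; within the scatter), which shows no real change. The steps of an at least 1.1-fold lower number from compound 1 to compound 2 (0.07 log units; that floor lies within the scatter) and an at least 1.3-fold lower number from compound 1 to compound 3 (0.14 log units; that floor lies within the scatter) start from the limit, so they give only floors, and these add little. One comparable step is thin evidence, but it points to no shift beyond the scatter, and the estimated step is a 1.1-fold lower number from compound 3 to compound 4 (0.04 log units; within the scatter) as a result.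

For compound 4 the expected value is 33000 nM, with an estimated range from 15000 nM to 50000 nM in this assay.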

Compound 4, half-maximal inhibitory concentration: > 50000 nM
Compound 4 ended at the assay's limit; the forecaster's own chance of this, stated with the estimate: 20%; middle value at least 1.5-fold (0.18 log units) away from the limit.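

In this assay compound 4 gives > 50000 nM, which is a limit of the assay and not a number. The steps of an at least 1.3-fold higher number from compound 3 to compound 4 (0.14 log units; that floor lies within the scatter) and an at least 1.1-fold higher number from compound 2 to compound 4 (0.07 log units; that floor lies within the scatter) are floors only. The exchange cannot be called a real loss. The step between compound 1 and compound 4, both at the limit, cannot be read. What is new is that 3-fluoro-4-(trifluoromethyl)phenyl, a phenyl carrying only fluorine-bearing substituents, brings no number lower than those of compound 2 and compound 3 at this position, and the assay now gives no exact reading for a larger share of the set: the limit of > 50000 nM in this assay, at which 2 of the 4 values shown sit.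

Going by these compounds, how far compound 4 lies past its limit remains unknown, so the true size of its gap to compound 3 could be small or large. On these data alone, it also remains open whether a group of a different kind in place of the substituted phenyl on a carbonyl carbon, such as an amine or a longer carbon chain, would move the number beyond the scatter.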